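Working notes on the amide series

The source may hold more compounds than are shown below. What is called first, only, known or untested is meant among the compounds shown, and "the series" means these compounds.

Measured so far, all in a functional assay on KYSE-450 cells (Homo sapiens) for inhibition, read by MTT assay, with a stated time of 48 h; a lower number here means a stronger inhibitor, a higher number a weaker inhibitor:
Compound 1, `COc1ccc(CN(C(=O)CN=[N+]=[N-])c2cc(OC)c(OC)c(OC)c2)cc1O`, gives 160 nM.
Compound 2, `COc1ccc(CN(C(=O)/C=C/CBr)c2cc(OC)c(OC)c(OC)c2)cc1O`, gives 100 nM.
Compound 3, `C/C=C/C(=O)N(Cc1ccc(OC)c(O)c1)c1cc(OC)c(OC)c(OC)c1`, gives 67 nM.

Compound 3 has the lowest number of the three. Its gap to compound 2 is small, a 1.5-fold lower number from compound 2 to compound 3 (0.17 log units; within the scatter), so the two cannot be ordered; against compound 1 the gap is larger, a 2.4-fold lower number from compound 1 to compound 3 (0.38 log units; beyond the scatter), and is the only one beyond the scatter. The third measured step, a 1.6-fold lower number from compound 1 to compound 2 (0.20 log units; within the scatter), also stays within the scatter.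

The next compound is compound 4, `C=CC(=O)N(Cc1ccc(OC)c(O)c1)c1cc(OC)c(OC)c(OC)c1`. Against compound 3 the change is vinyl in place of prop-1-en-1-yl on a carbonyl carbon. All three measured steps alter the same carbonyl substituent, and the closest of them is the step from compound 2 to compound 3, which also shortens the chain by one heavy atom and gave a 1.5-fold lower number from compound 2 to compound 3 (0.17 log units; within the scatter). Nothing measured removes a carbon from the double-bonded chain itself, so the three steps only indicate that changes at this carbonyl have stayed modest. A step within the scatter, slightly toward a lower number if anything, is therefore expected in this assay.

Compound 4 is accordingly estimated at 55 nM, with a range of 20 nM to 150 nM. The expected step is a 1.2-fold lower number from compound 3 to compound 4 (0.09 log units; within the scatter).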

Compound 4, half-maximal inhibitory concentration: 160 nM
Compound 4: the middle estimate sits 2.9-fold (0.46 log units) below what was measured; measured number above the stated range.
By their numbers in this assay, from the lowest: compounds 3, 2, 1 and 4 (each within the scatter of the next, the first and the last beyond it).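

In this assay, among these compounds, replacing prop-1-en-1-yl with vinyl on a carbonyl carbon is the first measured change to the double-bonded chain itself, and it gives the series its second step beyond the scatter (a 2.4-fold higher number from compound 3 to compound 4 (0.38 log units; beyond the scatter)). Vinyl cannot be told apart from the other two groups at this carbonyl carbon, either 3-bromoprop-1-en-1-yl (a 1.6-fold higher number from compound 2 to compound 4 (0.20 log units; within the scatter)) or azidomethyl (no change at the digits printed from compound 1 to compound 4 (within the scatter)), so prop-1-en-1-yl now stands apart from both vinyl and azidomethyl, while 3-bromoprop-1-en-1-yl cannot be ordered against any of the three other groups. Nothing available accounts for the difference between prop-1-en-1-yl and vinyl.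

The compounds shown leave open whether a longer chain on the carbonyl carbon, such as but-1-en-1-yl, would keep the number of compound 3 (67 nM) or move it further, and whether the double bond is needed at all, which a saturated propyl group would test. They also leave open how an aminomethyl group or a carboxylic acid on the chain would compare at this carbonyl carbon.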